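Compound 4: a 3,4-dichlorophenyl group replaces 3-methoxyphenyl

A few compounds are considered here, and "the series" means these few. Any claim that something is new, unique, unknown or untested is made for them only; others in the source may bear on it.

Results so far in a functional assay on A549 cells (Homo sapiens) for antiproliferative activity, read by MTT assay, with a stated time of 72 h (a lower number here means a stronger inhibitor, a higher number a weaker inhibitor), are:
- compound 1 `COc1cc(-c2ncnn2-c2cccc(F)c2)cc(OC)c1OC` gives > 10000 nM as a limit
- compound 2 `COc1cc(-n2ncnc2-c2ccc(Cl)cc2)cc(OC)c1OC` gives > 10000 nM as a limit
- compound 3 `COc1cccc(-c2ncnn2-c2cc(OC)c(OC)c(OC)c2)c1` gives > 10000 nM as a limit

Compound 3 stands at > 10000 nM as a limit of the assay, not as a number. The other two compounds offer no firmer footing, and the picture so far is the limit of > 10000 nM in this assay, at which 3 of the 3 values shown sit, with no exact value anywhere.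

The next compound is compound 4 `COc1cc(-n2ncnc2-c2ccc(Cl)c(Cl)c2)cc(OC)c1OC` and it differs from compound 3 by one change (3,4-dichlorophenyl in place of 3-methoxyphenyl on an aromatic carbon) on an aromatic carbon of a five-membered aromatic ring with 3 nitrogen. Among the measured compounds shown here, the one measured step that swaps a group on this carbon is a step that the two limits leave unreadable from compound 2 to compound 3 and it offers no size to carry over.

Compound 2, with 4-chlorophenyl on that carbon, gives > 10000 nM as a limit. Resting on that value, no step beyond the scatter is expected in this assay and no direction can be argued. The expected size is a number no higher from compound 3 to compound 4 (the limit leaves the size open) as an estimate only.

For compound 4 the estimate is 10000 nM with an expected range from 3000 nM to 30000 nM and another limit is the likeliest report.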

Compound 4, half-maximal inhibitory concentration: > 10000 nM
Compound 4: no number, only a limit (the forecaster's own chance of this, stated with the estimate: 85%); the middle value sits exactly at the limit.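

In this assay compound 4 gives > 10000 nM, which is a limit of the assay and not a number. No step can be read among compound 2, compound 3 and compound 4, because all of them stop at the same limit: the limit of > 10000 nM in this assay, at which 4 of the 4 values shown sit.

The compounds shown leave open how strongly any of them acts in this assay, and which changes on the shared core would give an exact value.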